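Replacing a fluorinated cyclohexyl with a pyridylmethyl on compound 3

This account rests on a few compounds, and the source may have more. Where it says the series, first, only, none or still open, it means among the compounds named here.

Compound 3 `FC1(F)CCC(NCc2ccc(CN(C[C@H]3Cc4ccccc4CN3)[C@H]3CCCc4cccnc43)cc2)CC1` stands at the weak end of the three measured compounds in a functional assay on cells for antagonist activity at C-X-C chemokine receptor type 4 (Homo sapiens), read by fluorescence and calcium flux, with stated times of 25 min and 90 s (on this read-out higher numbers stand for weaker inhibition and lower numbers for stronger inhibition), where compound 3 gives 143 nM. Compound 2 `c1ccc2c(c1)CN[C@@H](CN(CCCCNC1CCNCC1)[C@H]1CCCc3cccnc31)C2` gives 63.4 nM, and compound 1 `O=S1(=O)CCC(CNCCCCN(C[C@H]2Cc3ccccc3CN2)[C@H]2CCCc3cccnc32)CC1` gives 17 nM; the gaps from compound 3 to each of them lie beyond the scatter, so compound 3 is the least potent of the three. Among the compounds with values here, the only measured step that changes a single place is a 3.7-fold higher number from compound 1 to compound 2 (0.57 log units; beyond the scatter), a swap of groups on an amine nitrogen.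

Compound 4 `c1ccc2c(c1)CN[C@@H](CN(Cc1ccc(CNCc3ccncc3)cc1)[C@H]1CCCc3cccnc31)C2` differs from compound 3 by (pyridin-4-yl)methyl in place of 4,4-difluorocyclohexyl on an amine nitrogen. Within the data shown here, no measured step alters this amine nitrogen in this way; the step from compound 1 to compound 2 concerns another amine nitrogen and another pair of groups, so it shows only that exchanging the ring carried on an amine nitrogen can shift the number by a modest amount within this set. Lacking a closer precedent, the expected step of a 1.0-fold higher number from compound 3 to compound 4 (0.02 log units; within the scatter) is small and could fall in either direction, most likely not beyond the scatter. Compound 4 is therefore estimated at 150 nM, with a range from 55 nM to 420 nM.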

Compound 4, half-maximal inhibitory concentration in the C-X-C chemokine receptor type 4 assay: 134 nM
Compound 4: the middle estimate sits 1.1-fold (0.05 log units) above what was measured, within the range that was stated.
By their numbers in the C-X-C chemokine receptor type 4 assay, from the lowest: compound 1; then compound 2; then compounds 4 and 3 (each within the scatter of the next).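

In the C-X-C chemokine receptor type 4 assay, exchanging 4,4-difluorocyclohexyl for (pyridin-4-yl)methyl on this amine nitrogen gives a 1.1-fold lower number from compound 3 to compound 4 (0.03 log units; within the scatter), so the two compounds cannot be told apart on this read-out. The earlier step, a 3.7-fold higher number from compound 1 to compound 2 (0.57 log units; beyond the scatter), involved a different pair of groups and lay beyond the scatter, so a ring exchange on an amine nitrogen need not shift this number. The new pair also brings results in a physicochemical assay for permeability, using PAMPA, with a stated time of 4 h, at pH 7.4, tested at 100 uM (on this read-out lower numbers stand for lower permeability and higher numbers for higher permeability), where compound 3 gives 5 nm/s and compound 4 gives 385 nm/s. For this one pair the same exchange leaves the receptor number within the scatter while the result in the physicochemical assay moves by a large step: the measured apparent permeability of compound 3, 5 nm/s, and of compound 4, 385 nm/s, a 77-fold higher number (1.89 log units; beyond the scatter)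

The compounds shown leave open which part of the exchange goes with that large step in the physicochemical assay, since the fluorine atoms, the pyridine ring nitrogen and the methyl link all differ at once. A plain cyclohexyl or a benzyl group on this amine nitrogen would separate these parts, and a pyridin-3-yl methyl group would test whether the place of the ring nitrogen matters in either read-out.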